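Removing the Ethyl Group from a Sulfonamide Oxime Ether

A few compounds are considered here, and "the series" means these few. Any claim that something is new, unique, unknown or untested is made for them only; others in the source may bear on it.

The account follows compound 1 `CCOC1=C(/C(C)=N/OCC(=O)Nc2c(F)cccc2F)N(C)S(=O)(=O)c2ccccc21` to compound 3 `C/C(=N\OCC(=O)Nc1c(F)cccc1F)C1=C(O)c2ccccc2S(=O)(=O)N1C`. In a functional assay on THP-1 cells (Homo sapiens) for inhibition, read by ELISA, with stated times of 2 h and 48 h (on this read-out lower numbers stand for stronger inhibition and higher numbers for weaker inhibition), compound 1 gives only a limit, > 20000 nM, and so stands at the edge of the assay rather than at a number. Compound 2 `COc1cccc(NC(=O)CO/N=C(\C)C2=C(O)c3ccccc3S(=O)(=O)N2C)c1` in this assay likewise gives only a limit, > 20000 nM. For the measured compounds named here, no measured step between compounds is at hand. Compound 3 differs from compound 1 by hydrogen in place of ethyl on an oxygen on an unsaturated carbon. The step expected here is a step that the limit leaves unreadable from compound 1 to compound 3, none beyond the scatter. Compound 3 is therefore estimated at 30000 nM, within a range from 8000 nM to 100000 nM, with a limit again the likely report.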

Compound 3, half-maximal inhibitory concentration: > 20000 nM
Compound 3: a limit, no number (the forecaster's own chance of this, stated with the estimate: 80%); the middle value is on the limit's open side.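

No step can be read from compound 1 or compound 2 to compound 3, as each value is only a limit: the limit of > 20000 nM in this assay, at which 3 of the 3 values shown sit. The compounds shown leave open how ethoxy compares with hydroxy, or 2,6-difluorophenyl with 3-methoxyphenyl, in strength of inhibition.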